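A few compounds are considered here, and "the series" means these few. Any claim that something is new, unique, unknown or untested is made for them only; others in the source may bear on it.

Two compounds share a core in which a phenoxy group sits on a pyridine N-oxide, and both have been tested in a functional assay on the whole organism with Mus musculus as the target, in the maximal electroshock model, with a stated time of 30 min; a higher number here means that more compound is needed for the effect, a lower number that less compound is needed. Compound 1 `Cc1cc[n+]([O-])cc1Oc1ccccc1` carries a methyl group on the aromatic carbon and gives 30 mg/kg in this assay. Going by the values given here, compound 2 `O=Cc1cc[n+]([O-])cc1Oc1ccccc1` carries a formyl group in its place and gives 300 mg/kg, so that the single measured step runs a 10-fold higher number from compound 1 to compound 2 (1.00 log units; beyond the scatter). Compound 2 thus stands at the higher of the two numbers, with compound 1 the lower of the two.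

The next compound, compound 3 `O=C(O)c1cc[n+]([O-])cc1Oc1ccccc1`, differs from compound 2 by hydroxy in place of hydrogen on a carbonyl carbon; one bond further out the change reads formyl to carboxy. Among the compounds with values here, no measured step covers this kind of change, and the one step that exists, from methyl to formyl, bears on it only loosely by showing that altering this substituent moved the number by a clear margin. Compound 3 is therefore expected to sit near compound 2 or somewhat higher, a step of a 1.3-fold higher number from compound 2 to compound 3 (0.12 log units; within the scatter) with considerable uncertainty. The estimate for compound 3 in this assay is 400 mg/kg, within a range from 100 mg/kg to 1000 mg/kg.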

Compound 3, minimum effective dose: > 300 mg/kg
Compound 3 gave a limit, no number (the forecaster's own chance of this, stated with the estimate: 30%); the middle value lies beyond the limit too.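

In this assay, compound 3 gives a limit of the assay and not a number: the limit of > 300 mg/kg in this assay, at which 1 of the 3 values shown sits. Carboxy in place of methyl on the aromatic carbon gives an at least 10-fold higher number from compound 1 to compound 3 (1.00 log units; beyond the scatter), so this is the second replacement of methyl at this place, after formyl, to move the number the same way, and both compounds that carry a replacement, compound 2 and compound 3, lie on the side needing more compound. Hydroxy in place of hydrogen on the carbonyl carbon gives a number no lower from compound 2 to compound 3 (the limit leaves the size open), which means that this change brought no return toward the number of compound 1.

The compounds shown leave open how far the carboxy compound lies from the formyl compound, and so whether this change on the carbonyl carbon has any real size in this model. They also leave open whether any group on this aromatic carbon can match or improve on methyl, since an amine, a methyl ester, a primary amide or a longer chain such as ethyl is not among them.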